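The source may report more compounds than this note shows. Statements on the series, on what has been measured and on what is new or still open speak of the compounds shown alone.

Working notes on the series, read in a functional assay on HeLa cells (Homo sapiens) for cytotoxicity, read by sulforhodamine B assay; a higher number here means a weaker inhibitor, a lower number a stronger inhibitor. Compound 1 `CC(C)C(NS(=O)(=O)c1ccc(Br)cc1)C1=CC(=O)c2c(O)ccc(O)c2C1=O` gives 7650 nM, compound 3 `CC(=O)c1ccc(S(=O)(=O)NC(C2=CC(=O)c3c(O)ccc(O)c3C2=O)C(C)C)cc1` gives 3820 nM, and compound 2 `CC(C)C(NS(=O)(=O)c1cccc(Br)c1)C1=CC(=O)c2c(O)ccc(O)c2C1=O` gives 860 nM. Compound 2 has the lowest number of the three, and its gaps to both others lie beyond the scatter.

Compound 4 `CC(NS(=O)(=O)c1cccc(Br)c1)C1=CC(=O)c2c(O)ccc(O)c2C1=O` keeps the 3-bromophenyl on the sulfonyl sulfur of compound 2 and changes the chain instead: methyl in place of isopropyl on a saturated chain carbon bound to a double-bonded ring carbon and a sulfonamide nitrogen. For the measured compounds named here, no measured step touches this chain carbon. All three measured steps alter the aryl group on the sulfonyl sulfur: an 8.9-fold lower number from compound 1 to compound 2 (0.95 log units; beyond the scatter), a 4.4-fold higher number from compound 2 to compound 3 (0.65 log units; beyond the scatter) and a 2.0-fold lower number from compound 1 to compound 3 (0.30 log units; within the scatter), the last within the scatter. Going by the values given here, they give no direction for the new change and show only how far single edits have moved the numbers so far.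

A modest step is expected, with a slight lean towards a higher number since compound 2 already stands at 860 nM, the low end of the series. This lean is weak, and a result within the scatter would not be surprising. The estimated move is a 2.3-fold higher number from compound 2 to compound 4 (0.37 log units; beyond the scatter). The estimated value for compound 4 is 2000 nM, with an expected range of 600 nM to 6000 nM.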

Compound 4, half-maximal inhibitory concentration: 6350 nM
Estimate against measurement, compound 4: 3.2-fold (0.50 log units) below; measured number outside the range, above it.
By their numbers in this assay, from the lowest: compound 2; then compounds 3, 4 and 1 (each within the scatter of the next).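

In this assay, the saturated chain carbon bound to a double-bonded ring carbon and a sulfonamide nitrogen turns out to be a sensitive position: methyl in place of isopropyl gives a 7.4-fold higher number from compound 2 to compound 4 (0.87 log units; beyond the scatter), a move of similar size to the aryl change an 8.9-fold lower number from compound 1 to compound 2 (0.95 log units; beyond the scatter). The low number of compound 2 therefore does not rest on the 3-bromophenyl alone, since compound 4 keeps that group and gives 6350 nM. No measurement available here bears on the reason for this step.

With only isopropyl and methyl shown at this carbon, both carrying the 3-bromophenyl, it stays open whether the number follows chain size or whether an ethyl, a cyclopropyl or a longer chain would match or improve on isopropyl. From the compounds shown here alone, it is also open whether the same change has a step of similar size with 4-bromophenyl or 4-acetylphenyl on the sulfonyl sulfur, and how an amine on the chain would read.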